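A few compounds are considered here, and "the series" means these few. Any claim that something is new, unique, unknown or untested is made for them only; others in the source may bear on it.

Measured so far:
compound 1 `CN(C)c1nc(NCc2ccc(C(=O)N3CCC(C(=O)NCc4ccc(F)cc4)CC3)cc2)c2ccccc2n1`, 5500 nM
compound 2 `CCNc1ncc(C)c(NCc2ccc(NC(=O)c3ccc(F)cc3)cc2)n1`, > 20000 nM

In a functional assay on SW480 cells (Homo sapiens) for inhibition, read by luminescence and resazurin assay, with a stated time of 3 days (on this read-out higher numbers stand for weaker inhibition and lower numbers for stronger inhibition), compound 1 gives 5500 nM, the only numerical result in the set. For compound 2 the value > 20000 nM is a limit of the assay rather than a number; this is the limit of > 20000 nM in this assay, at which 1 of the 2 values shown sits. Compound 1 therefore stands alone as the single quantified point, with nothing measured around it to show how a change at its core moves the read-out. Among the measured compounds shown here, no pair of measured compounds differs in one place, so no step is known.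

Compound 3 `CCCNc1nc(NCc2ccc(C(=O)N3CCC(C(=O)NCc4ccc(F)cc4)CC3)cc2)c2ccccc2n1` differs from compound 1 in one place: propylamino in place of dimethylamino on an aromatic carbon. For the measured compounds named here, with no measured step to lean on, the expectation for this assay is a modest step, if anything toward stronger inhibition, and quite possibly within the usual scatter. The estimated change is a 1.4-fold lower number from compound 1 to compound 3 (0.14 log units; within the scatter). Compound 3 is expected to give 4000 nM in this assay, with a range from 1500 nM to 12000 nM.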

Compound 3, half-maximal inhibitory concentration: 5700 nM
Estimate against measurement, compound 3: 1.4-fold (0.15 log units) below; measured number inside the range.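

The series now has its first measured step: in this assay, propylamino in place of dimethylamino on the aromatic carbon between two ring nitrogen atoms gives no separation between the two compounds (a 1.0-fold higher number from compound 1 to compound 3 (0.02 log units; within the scatter)). At this position, exchanging a group with 0 hydrogen-bond donors for one with 1 hydrogen-bond donor, and a branched attachment at nitrogen for a straight chain, therefore leaves the read-out within the scatter, so the position tolerates at least this one change on the core of compound 1. Nothing at hand gives a reason why this exchange leaves the read-out flat.

From the compounds shown here alone, whether that tolerance extends to other groups at this position stays open, for example a longer chain such as hexylamino, a ring amine such as morpholine, an unsubstituted amine or a carboxylic acid. Among the compounds shown here, also open is how the read-out responds to a change elsewhere on compound 1, such as at the fluorobenzyl amide, since the only step available lies at this one position.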